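Working notes: the step from compound 3 to compound 4

A few compounds are considered here, and "the series" means these few. Any claim that something is new, unique, unknown or untested is made for them only; others in the source may bear on it.

Measured in a functional assay on MT4 cells (Homo sapiens) for cytotoxicity; a higher number here means that more compound is tolerated, a lower number that less compound is tolerated
- compound 1 `Cc1cn(C2CC(N=[N+]=[N-])C(COC(=O)OCCCC(=O)OC(C)(C)C)O2)c(=O)[nH]c1=O` gives > 50000 nM (a limit)
- compound 2 `Cc1cn(C2CC(N=[N+]=[N-])C(COC(=O)OCCCCO)O2)c(=O)[nH]c1=O` gives > 50000 nM (a limit)
- compound 3 `Cc1cn(C2CC(N=[N+]=[N-])C(COC(=O)NCCCC(=O)O)O2)c(=O)[nH]c1=O` gives > 50000 nM (a limit)

Compound 3 stands at > 50000 nM, which is a limit and not a number. Among the measured compounds shown here, the whole series offers only (the limit of > 50000 nM in this assay, at which 3 of the 3 values shown sit), so no compound can be ranked against another.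

Compound 4 `Cc1cn(C2CC(N=[N+]=[N-])C(COC(=O)OCCCCCO)O2)c(=O)[nH]c1=O` is the next to be read. The change is (5-hydroxypentyl)oxy in place of (3-carboxypropyl)amino on a carbonyl carbon.

For the measured compounds named here, two measured steps bear on it. One is a step that the two limits leave unreadable from compound 1 to compound 2, made further out on the chain. The other is a step that the two limits leave unreadable from compound 2 to compound 3, made on the same carbonyl carbon and therefore the closer guide. Neither has a size that can be used, so the expectation rests on the shared limit alone.

In this assay the expected result is a number no higher from compound 3 to compound 4 (the limit leaves the size open), with no change beyond the scatter and no direction favoured. Compound 4 is expected at 50000 nM, with an estimated range of 20000 nM to 100000 nM, and most likely it will be reported only as a limit.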

Compound 4, half-maximal cytotoxic concentration: > 50000 nM
Compound 4 ended at the assay's limit (the forecaster's own chance of this, stated with the estimate: 80%); the middle value lies on the limit itself.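

In this assay compound 4 gives > 50000 nM, which is a limit and not a number. Among the compounds shown here, no step from compound 1, compound 2 or compound 3 to compound 4 can be read. The compounds shown leave open how far the tolerated concentration of each lies beyond the shared limit: the limit of > 50000 nM in this assay, at which 4 of the 4 values shown sit.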